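From Methoxy to Anilino on a Carbonyl Carbon

This account rests on a few compounds, and the source may have more. Where it says the series, first, only, none or still open, it means among the compounds named here.

In a functional assay on HEY cells (Homo sapiens) for cytotoxicity, read by MTT assay, with a stated time of 72 h (a higher number here means a weaker inhibitor, a lower number a stronger inhibitor), compound 2 `COC(=O)c1nc(Br)c2cccnc2c1N[C@H]1CC[C@H](N)CC1` gives no number, only the limit > 20000 nM.

For the measured compounds named here, its one measured relative is compound 1 `COc1ccc(CNC(=O)c2nc(Br)c3cccnc3c2N[C@H]2CC[C@H](N)CC2)cc1`, and in this assay compound 1 gives 4000 nM. The step that connects them is an at least 5.0-fold higher number from compound 1 to compound 2 (0.69 log units; beyond the scatter), with methoxy in place of (4-methoxybenzyl)amino on a carbonyl carbon. From the compounds shown here alone, its true size is unknown, since one end of it is a limit.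

Compound 3 `N[C@H]1CC[C@H](Nc2c(C(=O)Nc3ccccc3)nc(Br)c3cccnc23)CC1` has anilino in place of methoxy on a carbonyl carbon, a difference that counts as anilino in place of methoxy on a carbonyl carbon. Anilino is not the group carried by compound 1, so the measured step is only a partial guide to this change. Going by the values given here, it is still the only measured step that bears on it.

Because compound 1 gives 4000 nM a step toward a lower number in this assay is expected, beyond the scatter. The expected step is an at least 3.3-fold lower number from compound 2 to compound 3 (0.52 log units; beyond the scatter). For compound 3 the estimated value is 6000 nM, with an expected range of 1500 nM to 20000 nM.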

Compound 3, half-maximal inhibitory concentration: 1000 nM
Compound 3: middle estimate off by 6.0-fold (0.78 log units), on the high side; the whole stated range lies above it.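

In this assay, anilino on this carbonyl carbon gives an at least 20-fold lower number from compound 2 to compound 3 (1.30 log units; beyond the scatter), a step whose true size stays unknown, since the value for compound 2 is a limit and not a number: the limit of > 20000 nM in this assay, at which 1 of the 3 values shown sits.

For the compounds shown here, the earlier compounds showed only that one amide-type group, (4-methoxybenzyl)amino, stood apart from methoxy here, whereas compound 3 shows that a second one does too, and with a different group on the nitrogen. The two amides also differ from each other, and with phenyl in place of 4-methoxybenzyl on an amide-type nitrogen the result is a 4.0-fold lower number from compound 1 to compound 3 (0.60 log units; beyond the scatter), so the group carried on that nitrogen counts as well as the presence of the nitrogen itself.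

The compounds shown leave open whether the amide hydrogen or the aromatic ring accounts for the gain over methoxy, which a plain amino group or a methylamino group on the same carbonyl carbon would help to separate. They also leave open how 4-methoxyanilino would read, which would show whether the methoxy group or the methylene of the benzyl group underlies the gap between the two amides.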